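A few compounds are considered here, and "the series" means these few. Any claim that something is new, unique, unknown or untested is made for them only; others in the source may bear on it.

Measured compounds in this series:
Compound 1 `CCCCN(CCCC)S(=O)(=O)NC(=O)Oc1c(C(C)C)cccc1C(C)C`: 1900 nM; 1900 nM (2 entries) in an assay on liver for inhibition of sterol O-acyltransferase 1 (Rattus norvegicus), using microsomes; a lower number here means a stronger inhibitor, a higher number a weaker inhibitor
Compound 2 `CC(C)c1cccc(C(C)C)c1OC(=O)NS(=O)(=O)Nc1ccccc1`: 38100 nM in this assay
Compound 3 `CC(C)c1cccc(C(C)C)c1OC(=O)NS(=O)(=O)Oc1ccc(F)cc1F`: > 50000 nM in this assay, a limit and not a number

Compound 3 stands at the limit of > 50000 nM in this assay, at which 1 of the 3 values shown sits; no single number is known for it. Going by the values given here, of the three compounds, compound 1 with its dibutylamino group on the sulfonyl sulfur gives the lowest number, compound 2 with an anilino group a far higher one, and the only measured step at this position, an at least 1.3-fold higher number from compound 2 to compound 3 (0.11 log units; that floor lies within the scatter), reaches a floor that lies within the scatter.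

Compound 4 `COc1cccc(OC)c1OS(=O)(=O)NC(=O)Oc1c(C(C)C)cccc1C(C)C` differs from compound 3 by 2,6-dimethoxyphenyl in place of 2,4-difluorophenyl on an oxygen. Among the compounds with values here, no measured step exchanges one aryloxy group for another on this oxygen, so the expectation rests on compound 3 alone and on the step of an at least 1.3-fold higher number from compound 2 to compound 3 (0.11 log units; that floor lies within the scatter), which points to weak inhibition for aryloxy groups here. No movement beyond the scatter is expected, and a further limit rather than a number is the more likely outcome. For compound 4 the estimate in this assay is 60000 nM, ranging from 20000 nM to 200000 nM, which corresponds to an expected step that the limit leaves unreadable from compound 3 to compound 4.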

Compound 4, half-maximal inhibitory concentration: > 50000 nM
Compound 4: only a limit was reported (the forecaster's own chance of this, stated with the estimate: 60%); the middle value lies beyond the limit too.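

No step can be read between compound 3 and compound 4, since each is reported only as a limit: the limit of > 50000 nM in this assay, at which 2 of the 4 values shown sit. Going by these compounds, whether any aryloxy group on this oxygen gives a real number in this assay stays open, as does the order of these two groups.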